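Chromone dithiocarbamates: piperidine to morpholine swap, antiproliferative read-out

This account rests on a few compounds, and the source may have more. Where it says the series, first, only, none or still open, it means among the compounds named here.

Measured so far:
compound 1 `Cc1ccc2c(=O)c(CSC(=S)N3CCCCC3)coc2c1` — > 25000 nM, a limit of the assay.
compound 2 `Cc1ccc2c(=O)c(CSC(=S)N3CCOCC3)coc2c1` — 3800 nM.
compound 3 `CCOC(=O)c1cc(=O)c2cc(CSC(=S)N3CCCCC3)ccc2o1` — > 25000 nM, a limit of the assay.

For the measured compounds named here, in a functional assay on SW480 cells (Homo sapiens) for antiproliferative activity, read by MTT assay, with a stated time of 72 h (on this read-out lower numbers stand for stronger inhibition and higher numbers for weaker inhibition), the only counted step is an at least 6.5-fold lower number from compound 1 to compound 2 (0.81 log units; beyond the scatter), the change being (morpholin-4-yl in place of piperidin-1-yl on a thiocarbonyl carbon). Compound 3 sits at the same limit as compound 1, see (the limit of > 25000 nM in this assay, at which 2 of the 3 values shown sit), so the difference between the two cores is not broken down here beyond the two structures themselves.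

Compound 4 `CCOC(=O)c1cc(=O)c2cc(CSC(=S)N3CCOCC3)ccc2o1` is not yet measured. It differs from compound 3 by morpholin-4-yl in place of piperidin-1-yl on a thiocarbonyl carbon, the same change as from compound 1 to compound 2. A step of an at least 3.1-fold lower number from compound 3 to compound 4 (0.49 log units; beyond the scatter) is expected in this assay, resting on an at least 6.5-fold lower number from compound 1 to compound 2 (0.81 log units; beyond the scatter) alone, with the caution that compound 3 gives only a limit. Compound 4 is estimated at 8000 nM, between 1500 nM and 40000 nM.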

Compound 4, half-maximal inhibitory concentration: > 25000 nM
Compound 4: no number, only a limit (the forecaster's own chance of this, stated with the estimate: 35%); middle value at least 3.1-fold (0.49 log units) from the limit.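

Compound 3 and compound 4 each give only a limit, so no step between them can be read: the limit of > 25000 nM in this assay, at which 3 of the 4 values shown sit.

Going by these compounds, whether morpholin-4-yl in place of piperidin-1-yl changes the number on the core of compound 3, as it does on the core of compound 1, stays open.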